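Series notes: sulfonyl aryl exchange on the fluoro congener

This account rests on a few compounds, and the source may have more. Where it says the series, first, only, none or still open, it means among the compounds named here.

Measured so far:
compound 1 `Cc1ccc(S(=O)(=O)c2cnc3ccc(Cl)cc3c2N2CCC(C)CC2)cc1C` — 84%
compound 2 `CC1CCN(c2c(S(=O)(=O)c3ccc(Cl)c(Cl)c3)cnc3ccc(Cl)cc23)CC1` — 86%
compound 3 `Cc1ccc(S(=O)(=O)c2cnc3ccc(F)cc3c2N2CCC(C)CC2)cc1C` — 92%

In an assay on isolated protein for displacement of a labelled ligand from metabotropic glutamate receptor 5 (Homo sapiens), with a stated time of 60 min, tested at 1 uM (on this read-out lower numbers stand for less inhibition and higher numbers for more inhibition at the one concentration tested (going by the name of the read-out)), compound 3 gives the largest of the three numbers, yet both gaps are within the scatter: compound 2 stands close, compound 1 somewhat further. Compound 4 `CC1CCN(c2c(S(=O)(=O)c3ccc(Cl)c(Cl)c3)cnc3ccc(F)cc23)CC1` is the next candidate. Change: 3,4-dichlorophenyl in place of 3,4-dimethylphenyl on a sulfonyl sulfur. Among the measured compounds shown here, the one measured step that bears on this change is a number 2 percentage points higher from compound 1 to compound 2 (within the scatter), the same exchange on the chloro congener, which stayed within the scatter. For compound 4 no step beyond the scatter is therefore expected in this assay, and the estimated step is a number 1 percentage points higher from compound 3 to compound 4 (within the scatter). Compound 4 is accordingly expected to give about 93%, with a range from 84% to 99%.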

Compound 4, a percentage reported as inhibition, at one concentration (the size of the read-out at that concentration, not a potency): 91%
Estimate against measurement, compound 4: 2 percentage points above, and the stated range covers the measured number.
By their numbers in this assay, from the lowest: compounds 1, 2, 4 and 3 (each within the scatter of the next).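

On the fluoro core, 3,4-dichlorophenyl in place of 3,4-dimethylphenyl on the sulfonyl sulfur gives, in this assay, a number 1 percentage points lower from compound 3 to compound 4 (within the scatter), so this exchange has now been read on two cores without a step beyond the scatter: the same change on two cores in this assay, a number 2 percentage points higher (within the scatter) from compound 1 to compound 2 and a number 1 percentage points lower (within the scatter) from compound 3 to compound 4, 3 percentage points apart, within the scatter of two such steps. Fluoro in place of chloro on an aromatic carbon, now also read with 3,4-dichlorophenyl on the sulfonyl sulfur, gives a number 5 percentage points higher from compound 2 to compound 4 (within the scatter), and the two readings of this change agree: the same change on two cores in this assay, a number 8 percentage points higher (within the scatter) from compound 1 to compound 3 and a number 5 percentage points higher (within the scatter) from compound 2 to compound 4, 3 percentage points apart, within the scatter of two such steps.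

Readings at one concentration leave any potency differences among these compounds open. Also open, as far as these compounds go, is whether a phenyl group carrying a carboxylic acid or an amine on the sulfonyl sulfur would give a step beyond the scatter.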